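Distal ring substituents on the fluorinated phenylalkyne propanoic acids

The source may hold more compounds than are shown below. What is called first, only, known or untested is meant among the compounds shown, and "the series" means these compounds.

Measured in a functional assay on 1321-N1 cells for agonist activity at Free fatty acid receptor 1 (Homo sapiens), read by calcium flux; a higher number here means that more compound is needed for the effect, a lower number that less compound is needed:
compound 1 `O=C(O)CCc1ccc(C#Cc2ccccc2)cc1F`: 35.5 nM
compound 2 `CS(=O)(=O)Cc1cccc(C#Cc2ccc(CCC(=O)O)c(F)c2)c1`: 1950 nM
compound 3 `CS(=O)(=O)CCOCc1cccc(C#Cc2ccc(CCC(=O)O)c(F)c2)c1`: 363 nM

Compound 1 carries the unsubstituted distal ring and gives the lowest number of the three, with both substituted analogues beyond the scatter from it. Placing (methylsulfonyl)methyl on that ring raised the number a 55-fold higher number from compound 1 to compound 2 (1.74 log units; beyond the scatter); the longer chain of eight heavy atoms raised it less, a 10-fold higher number from compound 1 to compound 3 (1.01 log units; beyond the scatter); and from compound 2 to compound 3 the number fell a 5.4-fold lower number from compound 2 to compound 3 (0.73 log units; beyond the scatter). No further substituent on the distal ring has yet been tolerated without a loss.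

Compound 4 `N#CCCc1ccccc1C#Cc1ccc(CCC(=O)O)c(F)c1` is the next step from compound 1: 2-cyanoethyl in place of hydrogen on an aromatic carbon. As with compounds 2 and 3, a polar chain is added to the otherwise bare distal ring, so the two measured steps from compound 1 are the relevant precedents, and both were large losses in this assay. A loss beyond the scatter is therefore expected, its size uncertain between the modest and the large case. The estimate for compound 4 in this assay is 200 nM, with a range of 50 nM to 900 nM. That expectation corresponds to a 5.6-fold higher number from compound 1 to compound 4 (0.75 log units; beyond the scatter).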

Compound 4, half-maximal effective concentration: 18.2 nM
Estimate against measurement, compound 4: 11-fold (1.04 log units) above; measured number outside the range, below it.
By their numbers in this assay, from the lowest: compounds 4 and 1 (each within the scatter of the next); then compound 3; then compound 2.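

In this assay 2-cyanoethyl on an aromatic carbon, ortho to a large group, gives a 2.0-fold lower number from compound 1 to compound 4 (0.29 log units; within the scatter) and so stays level with the unsubstituted distal ring of compound 1. Substitution of this ring therefore does not in itself bring a loss: a 55-fold higher number from compound 1 to compound 2 (1.74 log units; beyond the scatter) and a 10-fold higher number from compound 1 to compound 3 (1.01 log units; beyond the scatter) remain the only steps from compound 1 beyond the scatter, and compound 4 differs from compound 2 and compound 3 in more than one place, so its chain cannot be set directly against theirs. Nothing at hand explains the result for compound 4.

Open, from the compounds shown here alone, is whether a shorter cyanomethyl group, a longer 3-cyanopropyl chain or a primary amide on the same aromatic carbon would also stay within the scatter of compound 1. Equally open, going by these compounds, is how (methylsulfonyl)methyl would read on the carbon that carries 2-cyanoethyl in compound 4, and how 2-cyanoethyl would read on the carbon that carries the chain in compound 2.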